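The source may hold more compounds than are shown below. What is called first, only, known or untested is meant among the compounds shown, and "the series" means these compounds.

Measured so far, in a functional assay on MCF7 cells (Homo sapiens) for antiproliferative activity, read by MTT assay, with a stated time of 48 h; on this read-out lower numbers stand for stronger inhibition and higher numbers for weaker inhibition:
Compound 1 `COc1ccccc1-n1nncc1CN1C(=O)C2(C(C#N)=C(N)Oc3c2c2nc4ccccc4nc2c2ccccc32)c2ccccc21` gives > 50000 nM, a limit of the assay and not a number.
Compound 2 `CCOc1ccccc1-n1nncc1CN1C(=O)C2(C(C#N)=C(N)Oc3c2c2nc4ccccc4nc2c2ccccc32)c2ccccc21` gives > 50000 nM, likewise a limit of the assay and not a number.

Compound 2 therefore stands at the limit, where both values shown sit (the limit of > 50000 nM in this assay, at which 2 of the 2 values shown sit). Among the compounds with values here, the single measured step, a step that the two limits leave unreadable from compound 1 to compound 2, is left unreadable by the two limits, so no size can be taken from it.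

Compound 3 `Cc1ccc(-n2nncc2CN2C(=O)C3(C(C#N)=C(N)Oc4c3c3nc5ccccc5nc3c3ccccc43)c3ccccc32)cc1C` differs from compound 2 by 3,4-dimethylphenyl in place of 2-ethoxyphenyl on an aromatic nitrogen. Within the data shown here, no measured step covers this change, and the one step has no readable size, so the numbers give no direction for this assay. With compound 2 at the limit, compound 3 is expected to remain near that limit as well, at an estimated 50000 nM with a range from 10000 nM to 200000 nM. The expected step is a number no higher from compound 2 to compound 3 (the limit leaves the size open), with a high chance that only a limit is reported again.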

Compound 3, half-maximal inhibitory concentration: > 50000 nM
Compound 3: only a limit was reported (the forecaster's own chance of this, stated with the estimate: 75%); the middle value lies on the limit itself.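

No step can be read between compound 1, compound 2 and compound 3, as all three values are limits and not numbers: the limit of > 50000 nM in this assay, at which 3 of the 3 values shown sit.

The compounds shown leave open whether 2-methoxyphenyl, 2-ethoxyphenyl and 3,4-dimethylphenyl differ at all in this assay, and whether the shared core can give a measurable value there.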